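Moving a hydroxy group: from compound 2 to compound 3

The source may hold more compounds than are shown below. What is called first, only, known or untested is meant among the compounds shown, and "the series" means these compounds.

In a functional assay on NCI-H322M cells (Homo sapiens) for inhibition, read by sulforhodamine B assay, with a stated time of 48 h (a lower number here means a stronger inhibitor of growth, a higher number a weaker inhibitor of growth), compound 1 (`O=C(Cc1csc2nc(-c3ccc(Br)cc3)cn12)N/N=C/c1ccccc1`) gives 19100 nM, while compound 2 (`O=C(Cc1csc2nc(-c3ccc(Br)cc3)cn12)N/N=C/c1ccccc1O`), which carries a hydroxy group in place of a hydrogen on an aromatic carbon, gives 2140 nM. Compound 2 thus holds the lower of the two numbers and is the stronger growth inhibitor of the pair. Compound 3 (`O=C(Cc1csc2nc(-c3ccc(Br)cc3)cn12)N/N=C/c1ccc(O)cc1`) has not yet been measured. It has the same atoms as compound 2, joined differently: 4-hydroxyphenyl in place of 2-hydroxyphenyl on a carbon with a double bond to nitrogen. In words, 4-hydroxyphenyl stands in place of 2-hydroxyphenyl on a carbon with a double bond to nitrogen. Among the compounds with values here, only one measured step bears on this change: an 8.9-fold lower number from compound 1 to compound 2 (0.95 log units; beyond the scatter). Within the data shown here, that step shows that adding the hydroxy group can matter, but no measured pair compares its positions, so the forecast is uncertain. A modest move towards weaker inhibition is expected, estimated as a 2.3-fold higher number from compound 2 to compound 3 (0.37 log units; beyond the scatter). This would give back part of the earlier gain, but not all of it. For compound 3 the estimate is 5000 nM, with an expected range from 1600 nM to 17000 nM.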

Compound 3, concentration for 50% growth inhibition: 4370 nM
For compound 3 the middle estimate is 1.1-fold (0.06 log units) above the measured one, and the stated range covers the measured number.
By their numbers in this assay, from the lowest: compound 2; then compound 3; then compound 1.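

Compound 3 shows that the gain from a hydroxy group is not tied to 2-hydroxyphenyl: in this assay, 4-hydroxyphenyl also improves on the hydroxy-free compound 1, with a 4.4-fold lower number from compound 1 to compound 3 (0.64 log units; beyond the scatter). Where the hydroxy group sits on the ring also matters, since moving it gives a 2.0-fold higher number from compound 2 to compound 3 (0.31 log units; beyond the scatter), so 2-hydroxyphenyl is the better of the two placements in this set, though 4-hydroxyphenyl still keeps a clear part of the gain. Nothing available here explains why the two placements differ.

Going by these compounds, whether the gain depends on the hydroxy group itself stays open, as a methoxy group or an amine at the same places on the ring would be needed to test this, and 3-hydroxyphenyl would show whether the remaining ring position follows the same trend. On these data alone, these three compounds also share one core and are compared in a single cell line, so it remains unknown whether 2-hydroxyphenyl would still lead with another group in place of the bromine or in other cells.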